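Swapping Chlorine for Fluorine on the Aryl Ketone

A few compounds are considered here, and "the series" means these few. Any claim that something is new, unique, unknown or untested is made for them only; others in the source may bear on it.

Of the compounds shown here, two sharing a pyrazole-linked enone core have been tested in a functional assay on NCI-H23 cells (Homo sapiens) for inhibition, read by sulforhodamine B assay, with a stated time of 48 h; on this read-out higher numbers stand for weaker inhibition of growth and lower numbers for stronger inhibition of growth. Compound 1 `COc1ccc(-c2cc(/C=C/C(=O)c3ccc(N)cc3)[nH]n2)cc1` gives 3220 nM in this assay. Compound 2 `COc1cc(-c2cc(/C=C/C(=O)c3ccc(Cl)c(Cl)c3)[nH]n2)cc(OC)c1OC` gives 23400 nM in this assay, which is the higher of the two numbers, and the gap to compound 1 lies beyond the usual scatter of such measurements, so compound 2 is the weaker growth inhibitor of the pair. The two differ in more than one place, so their values say nothing about any single change.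

Compound 3 `COc1cc(-c2cc(/C=C/C(=O)c3ccc(F)c(F)c3)[nH]n2)cc(OC)c1OC` has not yet been measured. It differs from compound 2 in one place: 3,4-difluorophenyl in place of 3,4-dichlorophenyl on a carbonyl carbon. Within the data shown here, no measured pair shows what this exchange does here, and the halogens on that ring are the only thing that moves. A step from compound 2 to compound 3 of about a 1.1-fold higher number from compound 2 to compound 3 (0.03 log units; within the scatter) in this assay is expected, that is, no shift beyond the scatter. On that basis compound 3 is estimated to give 25000 nM in this assay, with a plausible range from 8000 nM to 80000 nM.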

Compound 3, concentration for 50% growth inhibition: 2600 nM
Estimate against measurement, compound 3: 9.6-fold (0.98 log units) above; measured number outside the range, below it.
By their numbers in this assay, from the lowest: compounds 3 and 1 (each within the scatter of the next); then compound 2.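

In this assay, the halogens on this ring matter: 3,4-difluorophenyl in place of 3,4-dichlorophenyl on a carbonyl carbon gives a 9.0-fold lower number from compound 2 to compound 3 (0.95 log units; beyond the scatter), which means stronger inhibition of growth. Among these compounds, this is the first comparison in the set in which only one place changes, so the shift can be assigned to this exchange, even though the two groups have the same count of heavy atoms and the same count of hydrogen-bond donors and acceptors. No measurement shown here explains why the two halogens give such different results.

On these data alone, it remains open whether both fluorines are needed and whether the trend extends to other substituents, such as a single fluorine, two bromine atoms or a trifluoromethyl group on the same ring. Compound 1 differs from compound 2 and compound 3 in more than one place, so it cannot show whether this exchange would have the same effect with a different group on the other side of the shared core.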